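Cytotoxicity notes: piperazine for pyrazole on the shared core

The source may report more compounds than this note shows. Statements on the series, on what has been measured and on what is new or still open speak of the compounds shown alone.

Compound 1 `O=c1nc(-c2ccccc2)c2cc(-c3cccnc3)ccc2[nH]1`: in an ADME assay on THP-1 cells (Homo sapiens) for cytotoxicity, read by MTT assay, with a stated time of 72 h (on this read-out higher numbers stand for an effect only at larger amounts of compound and lower numbers for an effect already at smaller amounts), compound 1 gives > 50000 nM, a limit of the assay.
Compound 2 `N#Cc1ccc(-c2ccc3[nH]c(=O)nc(-c4ccccc4)c3c2)cc1`: in this assay compound 2 gives > 50000 nM, also a limit.
Compound 3 `Cn1nccc1-c1ccc2[nH]c(=O)nc(-c3ccccc3)c2c1`: in this assay compound 3 gives > 50000 nM, again a limit.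

Compound 3 thus stands at the limit of > 50000 nM in this assay, at which 3 of the 3 values shown sit. The steps a step that the two limits leave unreadable from compound 1 to compound 3 and a step that the two limits leave unreadable from compound 2 to compound 3 both end at that limit and give no readable size, as does a step that the two limits leave unreadable from compound 1 to compound 2. The next change is 4-methylpiperazin-1-yl in place of 1-methyl-1H-pyrazol-5-yl on an aromatic carbon, giving compound 4 `CN1CCN(c2ccc3[nH]c(=O)nc(-c4ccccc4)c3c2)CC1`. Among the measured compounds shown here, no measured step bears on a non-aromatic ring in this place. With every value in this assay at the limit, the step expected is a number no higher from compound 3 to compound 4 (the limit leaves the size open), that is none beyond the scatter. Compound 4 is therefore expected near 50000 nM, within 20000 nM to 100000 nM, most likely reported again as a limit.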

Compound 4, half-maximal effective concentration: > 50000 nM
Compound 4 gave a limit, no number; the forecaster's own chance of this, stated with the estimate: 70%; the middle value lies on the limit itself.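

The steps to compound 4 from compound 1, compound 2 and compound 3 cannot be read: the limit of > 50000 nM in this assay, at which 4 of the 4 values shown sit.

The compounds shown leave open how far any of these groups moves the read-out in this assay, as none gives a number.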